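The source may report more compounds than this note shows. Statements on the series, on what has been measured and on what is new or still open speak of the compounds shown alone.

Compound 1 `COc1ccc(C=c2s/c(=C3\C(=O)Nc4cc(F)ccc43)n(CCN(C)C)c2=O)cc1` gives 2300 nM in a functional assay on HT-29 cells (Homo sapiens) for inhibition, read by MTT assay, with a stated time of 72 h; on this read-out lower numbers stand for stronger inhibition and higher numbers for weaker inhibition; compound 2 `CCN(CC)CCCn1c(=O)c(=Cc2ccc(F)c(F)c2)s/c1=C1\C(=O)Nc2cc(F)ccc21` gives 28 nM; compound 3 `CCN(CC)CCCn1c(=O)c(=Cc2ccccc2O)s/c1=C1\C(=O)Nc2ccc(Br)cc21` gives 18100 nM.

Among these three numbers compound 1 stands second highest: compound 3 lies well above it, beyond the scatter, while compound 2 lies far below it, also beyond the scatter. Compound 4 `CN(C)CCn1c(=O)c(=Cc2ccc(C=O)c(C=O)c2)s/c1=C1\C(=O)Nc2cc(F)ccc21` has not yet been measured in this assay. It differs from compound 1 in one place: 3,4-diformylphenyl in place of 4-methoxyphenyl on a double-bonded chain carbon bound to an aromatic carbon. Going by the values given here, no measured pair shows this particular change, so its size is not known from the data. A modest step from compound 1 to compound 4 is expected, most likely toward a somewhat higher number, the estimated step being a 1.5-fold higher number from compound 1 to compound 4 (0.18 log units; within the scatter). Compound 4 is accordingly expected to give about 3500 nM, within a range from 600 nM to 18000 nM.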

Compound 4, half-maximal inhibitory concentration: 1360 nM
Estimate against measurement, compound 4: 2.6-fold (0.41 log units) above, within the range that was stated.
By their numbers in this assay, from the lowest: compound 2; then compounds 4 and 1 (each within the scatter of the next); then compound 3.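

In this assay, placing 3,4-diformylphenyl in place of 4-methoxyphenyl on a double-bonded chain carbon bound to an aromatic carbon gives a 1.7-fold lower number from compound 1 to compound 4 (0.23 log units; within the scatter), so the two compounds cannot be told apart. Going by these compounds alone, this position therefore carries either group on the core of compound 1 with no difference that the assay resolves, the first direct reading of this place. Nothing available explains this result. Open, from the compounds shown here alone, is whether a carboxylic acid or an amine in place of the two formyl groups would also read the same.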